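The source may report more compounds than this note shows. Statements on the series, on what has been measured and on what is new or still open speak of the compounds shown alone.

In a toxicity assay on cells (Macrophage, Mus musculus, strain BALB/c) for cytotoxicity, read by MTT assay (a lower number here means a stronger inhibitor, a higher number a weaker inhibitor), compound 1, `COc1cc(O)cc(O)c1C(=O)/C=C/c1ccc(C(F)(F)F)cc1`, gives 17100 nM. Of the two numbers in hand it is the higher; compound 3, `C=CCOc1cc(OC)c(C(=O)/C=C/c2ccccc2Br)c(OCC=C)c1`, gives 5400 nM, a gap beyond the usual scatter. Compound 2, `COCc1cc(COC)c(C(=O)/C=C/c2ccc(OC)cc2)c(OC)c1`, reaches only a limit in this assay, > 250000 nM. That value sits at the limit of > 250000 nM in this assay, at which 1 of the 3 values shown sits. Compound 4, `COc1cc(O)cc(O)c1C(=O)/C=C/c1ccc(O)cc1`, has not yet been measured in this assay. It differs from compound 1 in one place: hydroxy in place of trifluoromethyl on an aromatic carbon. Going by the values given here, no step between two measured compounds is known here, so the expectation rests on these three values and the change itself. The change is expected to weaken inhibition, with an estimated step of a 2.3-fold higher number from compound 1 to compound 4 (0.37 log units; beyond the scatter). Compound 4 is accordingly estimated at 40000 nM, between 12000 nM and 150000 nM.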

Compound 4, half-maximal inhibitory concentration: 21700 nM
The estimate for compound 4 lay 1.8-fold (0.27 log units) above the measured number; the measured number falls inside the stated range.
By their numbers in this assay, from the lowest: compound 3; then compounds 1 and 4 (each within the scatter of the next). At a limit, above all of these: compound 2.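

In this assay, the change to hydroxy in place of trifluoromethyl on an aromatic carbon, para to a large group, gives a 1.3-fold higher number from compound 1 to compound 4 (0.10 log units; within the scatter), so in this one pair the two groups cannot be told apart. The earlier compounds shown here differ from one another in more than one place and could not isolate this position. No measurement shown here accounts for this result. From the compounds shown here alone, whether an amine, a carboxylic acid or a longer chain at this position would also stay within the scatter remains open, as does whether the same change would behave alike on the core of compound 3.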